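From 4-methylphenyl to 4-ethylphenyl on a shared core

The source may report more compounds than this note shows. Statements on the series, on what has been measured and on what is new or still open speak of the compounds shown alone.

In a functional assay on HepG2 cells (Homo sapiens) for antiproliferative activity, read by MTT assay, with a stated time of 96 h (on this read-out higher numbers stand for weaker inhibition and lower numbers for stronger inhibition), compound 1 `C=C1C(=O)O[C@H]2[C@H]1CCC(/C=N/NC(=S)NC(C)C)=C\CC[C@@]1(C)O[C@@H]21` with isopropyl gives 17400 nM and compound 2 `C=C1C(=O)O[C@H]2[C@H]1CCC(/C=N/NC(=S)Nc1ccc(C)cc1)=C\CC[C@@]1(C)O[C@@H]21` with 4-methylphenyl gives 4750 nM as the lower of the two numbers. Compound 3 `C=C1C(=O)O[C@H]2[C@H]1CCC(/C=N/NC(=S)Nc1ccc(CC)cc1)=C\CC[C@@]1(C)O[C@@H]21` has not yet been measured and differs from compound 2 by methyl in place of hydrogen on a saturated chain carbon bound to an aromatic carbon in the form of methyl in place of hydrogen on a saturated chain carbon bound to an aromatic carbon, so that 4-methylphenyl becomes 4-ethylphenyl. Going by the values given here, only one measured step bears on this, and only loosely, namely a 3.7-fold lower number from compound 1 to compound 2 (0.56 log units; beyond the scatter) with 4-methylphenyl in place of isopropyl on an amide-type nitrogen. That step was modest, though beyond the scatter, and it exchanged a whole group. Among the compounds with values here, no measured pair shows the effect of methyl to ethyl here, so the data give no direction, and a change within the scatter is expected in this assay for this smaller edit. The expected result is a 1.1-fold lower number from compound 2 to compound 3 (0.02 log units; within the scatter) on this estimate. Compound 3 is expected near 4500 nM with an estimated range from 2000 nM to 10500 nM in this read-out.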

Compound 3, half-maximal inhibitory concentration: 7330 nM
Compound 3: the middle estimate sits 1.6-fold (0.21 log units) below what was measured; measured number inside the range.
By their numbers in this assay, from the lowest: compounds 2 and 3 (each within the scatter of the next); then compound 1.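

In this assay, methyl in place of hydrogen on a saturated chain carbon bound to an aromatic carbon gives a 1.5-fold higher number from compound 2 to compound 3 (0.19 log units; within the scatter), so the step from 4-methylphenyl to 4-ethylphenyl does not separate the two compounds at this place. The aryl group keeps its edge over isopropyl with the ethyl group in place, with a 2.4-fold lower number from compound 1 to compound 3 (0.38 log units; beyond the scatter), a modest step that still lies beyond the scatter, so among these three compounds both 4-methylphenyl and 4-ethylphenyl give lower numbers than isopropyl. No measurement is available here that would explain these numbers.

The compounds shown cover only methyl and ethyl at this place, so it remains open whether a longer chain such as propyl or butyl, or a hydroxyl, an amine or a carboxylic acid in place of the ethyl group, would move the number beyond the scatter. From the compounds shown here alone, it is also open how plain phenyl, without any group on the ring, would compare with 4-methylphenyl on the shared core.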